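A few compounds are considered here, and "the series" means these few. Any claim that something is new, unique, unknown or untested is made for them only; others in the source may bear on it.

In an ADME assay on J774 cells (Mus musculus) for antiproliferative activity, with a stated time of 72 h (a lower number here means that less compound is needed, a higher number that more compound is needed for the effect), compound 1 (`CCCCc1cc2c(=O)cc(C)[nH]c2cc1OCCOc1ccccc1`) gives 28000 nM. Within the data shown here, compound 3 (`CCCCc1cc2c(=O)c(-c3ccccc3)c(C)[nH]c2cc1OCCOc1ccccc1`) gives 23000 nM, so compound 3 stands within the scatter of the only other number available. For compound 2 (`CCc1c(C)[nH]c2cc(OCCCOC(=O)C(CC)C(C)=O)c(Cl)cc2c1=O`) the result in this assay reads "not determined" (no result reported), and it offers no comparison.

Compound 4 (`CCCCc1cc2c(=O)c(-c3cccnc3)c(C)[nH]c2cc1OCCOc1ccccc1`) differs from compound 3 in one place, with pyridin-3-yl in place of phenyl on an aromatic carbon. Among the measured compounds shown here, only one measured step bears on this change. It concerns the same aromatic carbon, where phenyl replaces hydrogen, and it amounts to a 1.2-fold lower number from compound 1 to compound 3 (0.09 log units; within the scatter). For the measured compounds named here, no measured step exchanges one ring for another at this carbon, so the evidence is indirect. Since even adding the phenyl at this carbon in compound 3 gave only a 1.2-fold lower number from compound 1 to compound 3 (0.09 log units; within the scatter), no shift beyond the scatter is expected in this assay, and no direction is favoured. The expected change is a 1.1-fold higher number from compound 3 to compound 4 (0.04 log units; within the scatter). For compound 4 the estimated value is 25000 nM, with an expected range from 11000 nM to 50000 nM.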

Compound 4, half-maximal effective concentration: 23000 nM
Compound 4: the middle estimate sits 1.1-fold (0.04 log units) above what was measured; the measured number falls inside the stated range.
By their numbers in this assay, from the lowest: compounds 3, 4 and 1 (each within the scatter of the next).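

In this assay, among these compounds, the exchange of one ring for another on this aromatic carbon gives no change at the digits printed from compound 3 to compound 4 (within the scatter) and so provides the first direct measurement of such a swap at this position: the entering pyridin-3-yl, with its ring nitrogen and hydrogen-bond acceptor, leaves the number within the scatter of phenyl. Pyridin-3-yl in place of hydrogen gives a 1.2-fold lower number from compound 1 to compound 4 (0.09 log units; within the scatter) and, like phenyl, stays within the scatter, so neither aromatic ring tested on this carbon produces a step beyond it. Nothing available explains this outcome.

Going by these compounds, whether a carboxylic acid, an amine or a saturated ring such as piperidine on this carbon would move the number beyond the scatter remains open. Also open, on these data alone, is whether pyridin-3-yl would behave the same way with a longer chain in place of the butyl group on the shared core.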